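From Acetyl to Ethoxycarbonyl in an Unreadable Series

The compounds below may be only part of what the source reports. "The series", "measured", "known", "first", "only" and "open" are said of these compounds alone.

Values in a functional assay on Ehrlich cells (Mus musculus) for antiproliferative activity; on this read-out lower numbers stand for stronger inhibition and higher numbers for weaker inhibition:
- compound 1 `CC(=O)c1nn(-c2ccccc2)cc1C(=O)c1c(C(=O)Nc2ccccc2)nn(-c2ccccc2)c1C`: > 100 ug/mL
- compound 2 `CC(=O)c1nn(-c2ccc(C)cc2)cc1C(=O)c1c(C(=O)Nc2ccccc2)nn(-c2ccccc2)c1C`: > 100 ug/mL
- compound 3 `CC(=O)c1nn(-c2ccc(Br)cc2)cc1C(=O)c1c(C(=O)Nc2ccccc2)nn(-c2ccccc2)c1C`: > 100 ug/mL

Compound 1 stands at > 100 ug/mL, which is a limit of the assay and not a number. Compound 2 and compound 3 also have only limits, so the whole set sits at the limit of > 100 ug/mL in this assay, at which 3 of the 3 values shown sit.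

The next compound, compound 4 `CCOC(=O)c1nn(-c2ccccc2)cc1C(=O)c1c(C(=O)Nc2ccccc2)nn(-c2ccccc2)c1C`, keeps the core of compound 1 and changes one group: ethoxy in place of methyl on a carbonyl carbon. This is ethoxy in place of methyl on a carbonyl carbon, so acetyl becomes ethoxycarbonyl.

The measured steps all involve a change on an aromatic carbon, not on a carbonyl carbon. They are a step that the two limits leave unreadable from compound 1 to compound 2, a step that the two limits leave unreadable from compound 1 to compound 3 and a step that the two limits leave unreadable from compound 2 to compound 3. None has a readable size, so none measures the new change directly.

Within the data shown here, the only guide is that compound 1, compound 2 and compound 3 all sit at the limit of > 100 ug/mL in this assay, at which 3 of the 3 values shown sit. A further reading at the limit in this assay is therefore the expected outcome, with no clear gain in inhibition. The expected change is a step that the limit leaves unreadable from compound 1 to compound 4. For compound 4 the estimated value is 150 ug/mL, within an expected range from 50 ug/mL to 400 ug/mL.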

Compound 4, half-maximal inhibitory concentration: > 100 ug/mL
Compound 4 was reported as a limit; the forecaster's own chance of this, stated with the estimate: 80%; the middle value lies beyond the limit too.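

Compound 1 and compound 4 are both reported only as limits of the assay and not as numbers, so the change from acetyl to ethoxycarbonyl has no readable size. All the compounds shown share the same result: the limit of > 100 ug/mL in this assay, at which 4 of the 4 values shown sit. They leave open how strongly any of them acts in this assay, and whether ethoxycarbonyl differs from acetyl at all.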